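Swapping methoxy for nitro on the aryl amine of compound 1

The compounds below may be only part of what the source reports. "The series", "measured", "known", "first", "only" and "open" are said of these compounds alone.

Measured so far in a functional assay on the whole organism (strain Wistar albino) for inhibition, with Rattus norvegicus as the target, read by paw edema, with stated times of 30 min and 1 h, at a dose of 20 mg/kg by the oral route; a higher number here means more inhibition at the dose given (going by the name of the read-out), a lower number less inhibition:
compound 1 `COc1ccc(NCC(=O)Oc2ccc3c(C)cc(=O)oc3c2)cc1` gives 30.3%
compound 2 `Cc1cc(=O)oc2cc(OC(=O)CNc3ccccc3Cl)ccc12` gives 21.4%
compound 3 `Cc1cc(=O)oc2cc(OC(=O)CNc3nccs3)ccc12` gives 39.2%

Among the compounds with values here, compound 1 stands second highest of the three numbers, and both of its neighbours lie within the scatter of it: the step of a number 8.9 percentage points lower from compound 1 to compound 2 (within the scatter) and the step of a number 8.9 percentage points higher from compound 1 to compound 3 (within the scatter) each fall inside the usual spread, while only the step of a number 17.8 percentage points higher from compound 2 to compound 3 (beyond the scatter) reaches beyond it. All three compounds share one core and differ only in the group on the amine nitrogen.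

Compound 4 `Cc1cc(=O)oc2cc(OC(=O)CNc3ccc([N+](=O)[O-])cc3)ccc12` keeps the ring of compound 1 and changes a single substituent on it: nitro in place of methoxy on an aromatic carbon. Within the data shown here, no measured step swaps one group on that ring for another; each measured step replaces the whole group on the nitrogen, and even those larger changes moved the numbers little from compound 1. For compound 4 the expectation in this assay is therefore a step of a number 0.3 percentage points lower from compound 1 to compound 4 (within the scatter), not beyond the scatter, with an estimated value of 30% and a range from 18% to 42%.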

Compound 4, a percentage reported as inhibition, in the whole organism at one dose (the size of the read-out at that dose, not a potency): 12.5%
The estimate for compound 4 lay 17.5 percentage points above the measured number, and the stated range ends above it.
By their numbers in this assay, from the lowest: compounds 4, 2, 1 and 3 (each within the scatter of the next, the first and the last beyond it).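

In this assay, the change from methoxy to nitro gives a number 17.8 percentage points lower from compound 1 to compound 4 (beyond the scatter). This is the first step shown that alters only one substituent on the aromatic ring, at the place para to a large group, and it shows that the number responds to that substituent. Replacing the whole group on the nitrogen moved the number from compound 1 only within the scatter, yet this smaller change goes beyond it, so a small edit here can matter more than a larger one elsewhere. Nothing shown explains the drop.

As far as these compounds go, it remains open whether the drop comes from losing methoxy or from gaining nitro, since only these two groups have been compared at this place. An amine, a methyl group or a simple hydrogen there would help separate the two.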